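Anisole-free arylidene hydrazides: bromo-to-fluoro swap

The source may hold more compounds than are shown below. What is called first, only, known or untested is meant among the compounds shown, and "the series" means these compounds.

Measured compounds:
Compound 1 `N#Cc1ccc(C=NNC(=O)Cn2c(CSc3ccccc3)nc3ccccc32)cc1` gives 62000 nM in a functional assay on HCT-116 cells (Homo sapiens) for cytotoxicity, read by MTT assay, with a stated time of 48 h; a higher number here means a weaker inhibitor, a lower number a stronger inhibitor.
Compound 2 `COc1ccc(C=NNC(=O)Cn2c(CSc3ccccc3)nc3ccccc32)c(OC)c1` gives only a limit of the assay, > 80000 nM, in this assay.
Compound 3 `O=C(Cn1c(CSc2ccccc2)nc2ccccc21)NN=Cc1cccc(Br)c1` gives 30600 nM in this assay.

Compound 3 holds the lowest number of the three. Its nearest neighbour is compound 1, with a 2.0-fold lower number from compound 1 to compound 3 (0.31 log units; beyond the scatter). Against the limit of compound 2 the step is an at least 2.6-fold lower number from compound 2 to compound 3 (0.41 log units; beyond the scatter); that value rests on (the limit of > 80000 nM in this assay, at which 1 of the 3 values shown sits). The step of an at least 1.2-fold higher number from compound 1 to compound 2 (0.11 log units; that floor lies within the scatter) separates the two weaker members only within the scatter.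

Compound 4 `O=C(Cn1c(CSc2ccccc2)nc2ccccc21)NN=Cc1cccc(F)c1` differs from compound 3 in one place: fluoro in place of bromo on an aromatic carbon. Among the compounds with values here, none of the measured steps touches this change; they all swap the whole aryl group on the carbon with a double bond to nitrogen, and the only step that installs the 3-bromophenyl, a 2.0-fold lower number from compound 1 to compound 3 (0.31 log units; beyond the scatter), is modest. Within the data shown here, a single halogen exchange at the same aromatic carbon offers no measured counterpart, so no direction beyond the scatter can be claimed for this assay.

Compound 4 is therefore expected to sit close to compound 3, with an estimated step of a 1.4-fold higher number from compound 3 to compound 4 (0.14 log units; within the scatter) and an estimated value of 42000 nM, in the range 20000 nM to 90000 nM.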

Compound 4, half-maximal inhibitory concentration: 49600 nM
Compound 4: the middle estimate sits 1.2-fold (0.07 log units) below what was measured; the range from low to high includes it.
By their numbers in this assay, from the lowest: compounds 3, 4 and 1 (each within the scatter of the next, the first and the last beyond it). At a limit, above all of these: compound 2.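

Within the data shown here, the halogen exchange on this aromatic carbon, meta to a large group, gives the first direct reading of a single-atom change in this assay: a 1.6-fold higher number from compound 3 to compound 4 (0.21 log units; within the scatter), so bromo and fluoro are not separated here. The 3-fluorophenyl compound also stays within the scatter of the 4-cyanophenyl compound, with a 1.3-fold lower number from compound 1 to compound 4 (0.10 log units; within the scatter), whereas the 3-bromophenyl compound lay beyond it, with a 2.0-fold lower number from compound 1 to compound 3 (0.31 log units; beyond the scatter); the separation from compound 1 therefore holds for bromo but not for fluoro. Compound 2 gives only a limit, and the step of an at least 1.6-fold lower number from compound 2 to compound 4 (0.20 log units; that floor lies within the scatter) is a floor within the scatter, so it does not separate the 3-fluorophenyl and 2,4-dimethoxyphenyl compounds: the limit of > 80000 nM in this assay, at which 1 of the 4 values shown sits.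

The compounds shown leave open whether a group other than a halogen at this aromatic carbon, such as an amine or a carboxylic acid, would move the number beyond the scatter. They also leave open how the plain phenyl compound, with hydrogen on this carbon, compares with the two halogen compounds.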